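Phenoxy in place of phenylcarbamoyl on a shared core

The source may hold more compounds than are shown below. What is called first, only, known or untested is meant among the compounds shown, and "the series" means these compounds.

Compound 1 `O=C(Nc1ccccc1)c1cnc(NCc2c(F)ccc3c2CCO3)n2cnnc12`: 4.1
Compound 2 `Cn1cc(-c2cnc(NCc3c(F)ccc4c3CCO4)c3cn[nH]c(=O)c23)cn1`: 2.7

Of the two compounds measured in a physicochemical assay for lipophilicity, using the shake flask method, in phosphate buffer, measured as octanol-water partition, with a stated time of 30 min, at pH 7.4 (on this read-out higher numbers stand for higher lipophilicity and lower numbers for lower lipophilicity), compound 1 stands highest at 4.1. Compound 2 gives 2.7. The gap between these two compounds lies beyond the scatter. Compound 3 `Fc1ccc2c(c1CNc1ncc(Oc3ccccc3)c3nncn13)CCO2` keeps the core of compound 1 and changes one group: phenoxy in place of phenylcarbamoyl on an aromatic carbon. Within the data shown here, no measured pair shows this change. Both groups hold one six-membered aromatic ring of carbon only, and compound 1 at 4.1 is the starting point. The expected step of a number 0.20 log units lower from compound 1 to compound 3 (within the scatter) is small and stays within the scatter in this assay. Compound 3 is estimated at 3.9, with an expected range of 3.3 to 4.5.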

Compound 3, distribution coefficient: 3.5
Compound 3: the middle estimate sits 0.40 log units above what was measured, within the range that was stated.
By their numbers in this assay, from the lowest: compound 2; then compound 3; then compound 1.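

In this assay, among these compounds, phenoxy in place of phenylcarbamoyl on this aromatic carbon gives a number 0.60 log units lower from compound 1 to compound 3 (beyond the scatter) and this is the first measured step at this position. The six-membered aromatic ring of carbon only stays, while the hydrogen-bond donor and the double bond outside aromatic rings leave, and this single pair cannot separate those differences. Nothing shown here explains the step.

The compounds shown leave open how a group without that ring, such as an amine or a carboxylic acid, would read at this position. On these data alone, whether the same change gives a similar step on another core also remains open.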